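The source may report more compounds than this note shows. Statements on the series, on what has been measured and on what is new or still open speak of the compounds shown alone.

Measured compounds:
Compound 1 `COc1ccc(S(=O)(=O)c2cnc3cc(F)ccc3c2N2CCC(C)CC2)cc1OC`: 83%
Compound 2 `CC1CCN(c2c(S(=O)(=O)c3ccc(F)c(F)c3)cnc3ccc(F)cc23)CC1`: 82%
Compound 3 `COc1ccc(S(=O)(=O)c2cnc3cc(Cl)ccc3c2N2CCC(C)CC2)cc1OC`: 93%

In an assay on isolated protein for displacement of a labelled ligand from metabotropic glutamate receptor 5 (Homo sapiens), with a stated time of 60 min, tested at 1 uM (a lower number here means less inhibition, a higher number more inhibition at the concentration tested (going by the name of the read-out)), compound 1 gives 83%, and the two other measured compounds sit close to it: compound 2 gives 82% and compound 3 gives 93%, both within the scatter of compound 1. Among the compounds with values here, the only single-point step among them, a number 10 percentage points higher from compound 1 to compound 3 (within the scatter), concerns the halogen on the shared core and not the group on the sulfonyl sulfur.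

Compound 4 `CC1CCN(c2c(S(=O)(=O)c3cc(F)cc(F)c3)cnc3cc(F)ccc23)CC1` differs from compound 1 at that sulfur: 3,5-difluorophenyl in place of 3,4-dimethoxyphenyl on a sulfonyl sulfur. No measured step touches this position, so no shown step bears on it directly. Within the data shown here, compound 2, which carries a difluorophenyl on its sulfonyl sulfur but also a differently placed fluoro on the core, shows only that such a compound can reach a value like that of compound 1.

On this basis compound 4 is expected to stay in the same region as compound 1, with a number 3 percentage points lower from compound 1 to compound 4 (within the scatter) not beyond the scatter. The estimate for compound 4 in this assay is 80%, with a range from 60% to 93%.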

Compound 4, a percentage reported as inhibition, at one concentration (the size of the read-out at that concentration, not a potency): 77%
Estimate against measurement, compound 4: 3 percentage points above; the range from low to high includes it.
By their numbers in this assay, from the lowest: compounds 4, 2, 1 and 3 (each within the scatter of the next, the first and the last beyond it).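

Within the data shown here, the exchange of 3,4-dimethoxyphenyl for 3,5-difluorophenyl on the sulfonyl sulfur is the first change read directly at this position, and in this assay it amounts to a number 6 percentage points lower from compound 1 to compound 4 (within the scatter). An aryl group of carbon and fluorine alone, without the oxygen atoms of the 3,4-dimethoxyphenyl, therefore keeps the read-out at the tested concentration within the scatter of compound 1, though this single-concentration figure is not a potency. Nothing shown offers an explanation for this step.

The compounds shown leave open whether the group on the sulfonyl sulfur must be an aryl group at all, or whether one bearing an amine or a carboxylic acid would hold the value. Also open, as far as these compounds go, is how 3,5-difluorophenyl behaves on a core carrying chloro in place of fluoro.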